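One-carbon chain extension and lipophilicity across two cores

This account rests on a few compounds, and the source may have more. Where it says the series, first, only, none or still open, it means among the compounds named here.

Compound 1 `CCCCCNC(=O)c1ccc(S(N)(=O)=O)cc1` gives 1.54 in a physicochemical assay for lipophilicity; on this read-out lower numbers stand for lower lipophilicity and higher numbers for higher lipophilicity. Compound 2 `CCCCCCNC(=O)c1ccc(S(N)(=O)=O)cc1` differs from it by methyl in place of hydrogen on a saturated chain carbon, five bonds along the chain from an amide-type nitrogen, and in this assay compound 2 gives 2.05. The step is a number 0.51 log units higher from compound 1 to compound 2 (beyond the scatter), so one extra carbon on the chain shows up clearly in the read-out.

Compound 3 `CCCCOC(=O)c1cccc(S(N)(=O)=O)c1` carries a different core; how the two cores differ is not broken down here. In this assay compound 3 gives 2.24. Set against compound 2, the two values lie within the scatter of each other, so no order between them is read. Set against compound 1, the value of compound 3 is the higher of the two by more than the scatter.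

Compound 4 `CCCCCOC(=O)c1cccc(S(N)(=O)=O)c1` has not been measured. It differs from compound 3 by methyl in place of hydrogen on a saturated chain carbon, four bonds along the chain from an oxygen next to a carbonyl group. This is the same kind of change as methyl in place of hydrogen on a saturated chain carbon, five bonds along the chain from an amide-type nitrogen, but the place is not the same: in the amide pair the new carbon sits five bonds along the chain from an amide-type nitrogen, whereas in the ester pair it sits four bonds along the chain from an oxygen next to a carbonyl group. Since the chain end itself is unchanged in both cases, the measured step of a number 0.51 log units higher from compound 1 to compound 2 (beyond the scatter) is taken as the guide. The corresponding step is therefore expected to be about that size, namely a number 0.50 log units higher from compound 3 to compound 4 (beyond the scatter). On that basis compound 4 is estimated at 2.74, with a range from 2.45 to 3.05.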

Compound 4, partition coefficient: 2.71
For compound 4 the middle estimate is 0.03 log units above the measured one; measured number inside the range.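

Carried from the core of compound 1 to the core of compound 3, the same change of methyl in place of hydrogen gives two steps close in size in this assay: a number 0.51 log units higher from compound 1 to compound 2 (beyond the scatter) and a number 0.47 log units higher from compound 3 to compound 4 (beyond the scatter). Within these four compounds, the size of the step therefore carries over from one core to the other, even though the new carbon sits in a different place: four bonds along the chain from an oxygen next to a carbonyl group in one pair, and five bonds along the chain from an amide-type nitrogen in the other. This rests on a single pair for each core, so it does not establish a general rule for the series or separate the contribution of the core from that of the place on the chain, and nothing available explains why the two steps are alike.

The compounds shown leave open whether a step of this size would recur on a longer chain than any shown here, or on a branched chain. They also leave open how the same change would read in compounds carrying an amine or a carboxylic acid.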